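The source may report more compounds than this note shows. Statements on the series, on what has been measured and on what is new or still open speak of the compounds shown alone.

Measured so far in an ADME assay on Karpas-1106P cells (Homo sapiens) for cytotoxicity; on this read-out lower numbers stand for an effect already at smaller amounts and higher numbers for an effect only at larger amounts of compound:

compound 1 `Cc1ccc(S(=O)(=O)N[C@@H](CC(=O)NC(C)(C)C)C(=O)NCCNC(=O)c2cc(Cl)ccn2)cc1` gives > 11100 nM
compound 2 `COc1cc(OC)cc(C(=O)NCCNC(=O)[C@H](CC(=O)NC(C)(C)C)NS(=O)(=O)c2ccc(C)cc2)c1` gives > 11100 nM
compound 3 `Cc1ccc(S(=O)(=O)N[C@@H](CC(=O)NC(C)(C)C)C(=O)NCCNC(=O)c2cccc(F)c2)cc1` gives > 11100 nM

Each of these three values is a limit of the assay, not a number. Compound 2 therefore stands only at a limit in this assay, with no measured number of its own. All three values sit at the limit of > 11100 nM in this assay, at which 3 of the 3 values shown sit, so the series gives no read on cytotoxicity in this assay as yet.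

Compound 4 `Cc1ccc(S(=O)(=O)N[C@@H](CC(=O)NC(C)(C)C)C(=O)NCCNC(=O)c2ccccc2O)cc1` differs from compound 2 in one place: 2-hydroxyphenyl in place of 3,5-dimethoxyphenyl on a carbonyl carbon. The measured steps that bear on this position are a step that the two limits leave unreadable from compound 2 to compound 3, a step that the two limits leave unreadable from compound 1 to compound 2 and a step that the two limits leave unreadable from compound 1 to compound 3; none of them can be read in size, since both ends of each sit at the limit. Going by the values given here, no measured step at this position shows any effect beyond the scatter that could be carried over to compound 4. On that basis the step from compound 2 to compound 4 is expected to be a step that the limit leaves unreadable from compound 2 to compound 4, which is to say no readable step. Compound 4 is therefore expected to give 20000 nM, with a range from 8000 nM to 50000 nM, most likely again reported only as a limit in this assay.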

Compound 4, half-maximal effective concentration: > 11100 nM
Compound 4: only a limit was reported (the forecaster's own chance of this, stated with the estimate: 85%); the middle value is on the limit's open side.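

In this assay compound 4 gives > 11100 nM, again a limit and not a number, so its steps from compound 1, compound 2 and compound 3 cannot be read. The compounds shown leave open whether any group on this carbonyl carbon brings a measurable effect on cytotoxicity, with every value still at one limit: the limit of > 11100 nM in this assay, at which 4 of the 4 values shown sit.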